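A few compounds are considered here, and "the series" means these few. Any claim that something is new, unique, unknown or untested is made for them only; others in the source may bear on it.

Compound 1 `COc1cccc(-c2cc(C)c3ncc(CSCCc4ccccc4)n3c2)c1` gives 20 ug/mL.
Compound 2 `Cc1cc(-c2ccsc2)c2ncc(CSCCc3ccccc3)n2c1` gives 100 ug/mL.
Compound 3 `Cc1cc(-c2ccc(C#N)cc2)cn2c(CSCCc3ccccc3)cnc12` gives a limit of the assay, >= 20 ug/mL.

These three compounds were tested in an ADME assay on HEL cells (Homo sapiens) for cytotoxicity, with a stated time of 3 days; on this read-out higher numbers stand for lower toxicity in this test and lower numbers for higher toxicity in this test. Of the two plain numbers, compound 2 gives the higher one; its nearest neighbour is compound 1 with a lower number, and the gap between them lies beyond the scatter. The third value, that of compound 3, is only a limit.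

Compound 4 `Cc1cc(-c2cccc([N+](=O)[O-])c2)c2ncc(CSCCc3ccccc3)n2c1` has not yet been measured. It differs from compound 2 by 3-nitrophenyl in place of thiophen-3-yl on an aromatic carbon. For the measured compounds named here, the one measured step that resembles this change, an exchange of one aryl group for another at the same position, is a number no lower from compound 1 to compound 3 (the limit leaves the size open), whose size cannot be read because the limit of >= 20 ug/mL in this assay, at which 1 of the 3 values shown sits, is all that compound 3 shows. Going by the values given here, no measured step therefore gives a usable size for the change in hand.

Compound 4 is estimated at 40 ug/mL, between 10 ug/mL and 100 ug/mL. Among the compounds with values here, this estimate means a step of a 2.5-fold lower number from compound 2 to compound 4 (0.40 log units; beyond the scatter), expected because compound 1, the only other compound carrying a six-membered carbon ring in this place, gives 20 ug/mL.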

Compound 4, minimum cytotoxic concentration: 100 ug/mL
Beside the measured number, compound 4's estimate is 2.5-fold (0.40 log units) below it; the range from low to high includes it.
By their numbers in this assay, from the lowest: compound 1; then compounds 2 and 4 (each within the scatter of the next).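

In this assay, the new step shows that this position, on an aromatic carbon two atoms from the ring nitrogen, accepts a much larger aryl group without any visible effect: no change at the digits printed from compound 2 to compound 4 (within the scatter). Thiophen-3-yl and 3-nitrophenyl therefore cannot be told apart in this test, even though one is a five-membered ring with sulfur and the other a six-membered carbon ring carrying a nitro group. A six-membered carbon ring alone does not account for the lower number of compound 1, since compound 1 gives 20 ug/mL with 3-methoxyphenyl, whereas compound 4 gives 100 ug/mL with 3-nitrophenyl.

From the compounds shown here alone, the step to compound 3 with its 4-cyanophenyl group still cannot be read: the limit of >= 20 ug/mL in this assay, at which 1 of the 4 values shown sits. Also open is how this number would respond to a phenyl ring bearing an amine or a carboxylic acid, or to a simple alkyl chain in this place.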